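Cytotoxicity of isoquinoline analogues: from compound 3 to compound 4

A few compounds are considered here, and "the series" means these few. Any claim that something is new, unique, unknown or untested is made for them only; others in the source may bear on it.

Of the compounds shown here, three of one shared core have been tested in an ADME assay on MCF-10A cells (Homo sapiens) for cytotoxicity, read by CCK-8 assay and cell counting, with a stated time of 72 h; a lower number here means a stronger inhibitor, a higher number a weaker inhibitor. Compound 1 `COc1ccc(-c2cc3ccccc3c(-c3cccc(O)c3)n2)cc1` gives 7830 nM in this assay. Compound 2 `COc1ccc(-c2cc3ccccc3c(-c3cccc(N)c3)n2)cc1` gives 18800 nM. Among the measured compounds shown here, the step of a 2.4-fold higher number from compound 1 to compound 2 (0.38 log units; beyond the scatter) is the only single-point comparison among the measured compounds. For compound 3 `COc1cc(OC)cc(-c2cc3ccccc3c(-c3cccc(OC)c3)n2)c1` the assay reports only a limit, > 50000 nM, so compound 3 stands at the limit of > 50000 nM in this assay, at which 1 of the 3 values shown sits, and its true number is not known. Compound 4 `COc1cc(OC)cc(-c2cc3ccccc3c(-c3ccc(O)cc3)n2)c1` differs from compound 3 in one place: 4-hydroxyphenyl in place of 3-methoxyphenyl on an aromatic carbon. For the measured compounds named here, no measured step changes exactly this group, so the step to compound 4 is judged only loosely. The step from compound 1 to compound 2 shows that swapping a hydroxy for another group at this kind of position moved the number modestly. The hydroxy-bearing compound 1 sits well inside the measured range, so a number rather than a limit is expected for compound 4, with an at least 1.6-fold lower number from compound 3 to compound 4 (0.22 log units; that floor lies within the scatter) expected to lower it. Compound 4 is thus estimated at 30000 nM, between 8000 nM and 100000 nM.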

Compound 4, half-maximal inhibitory concentration: 7280 nM
Compound 4: the middle estimate sits 4.1-fold (0.61 log units) above what was measured; measured number below the stated range.
By their numbers in this assay, from the lowest: compounds 4 and 1 (each within the scatter of the next); then compound 2. At a limit, above all of these: compound 3.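

On the aromatic carbon next to the ring nitrogen, putting 4-hydroxyphenyl in place of 3-methoxyphenyl gives an at least 6.8-fold lower number from compound 3 to compound 4 (0.83 log units; beyond the scatter) in this assay. The earlier step only exchanged a hydroxy for an amino group on the ring at this place, whereas this one shows that replacing the whole group can bring a compound from a limit to a measured number. The true size of this step stays unknown because compound 3 is known only as a limit: the limit of > 50000 nM in this assay, at which 1 of the 4 values shown sits.

The change swaps methoxy for hydroxy and also moves the oxygen on the ring, so the compounds shown cannot tell which of the two carries the step. Going by these compounds, how a carboxylic acid or a longer chain in place of that hydroxy would read also remains open.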